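One side chain swap in a level series

The compounds below may be only part of what the source reports. "The series", "measured", "known", "first", "only" and "open" are said of these compounds alone.

In a functional assay on OVCAR-8 cells (Homo sapiens) for antiproliferative activity (on this read-out higher numbers stand for weaker inhibition and lower numbers for stronger inhibition), compound 1 (`Cn1ncc(Cl)c1-c1cc(C(=O)N[C@@H]2CN[C@H](CCn3cncn3)C[C@H]2c2ccc(Cl)c(Cl)c2)oc1Cl`) gives 1560 nM and compound 2 (`Cn1ncc(Cl)c1-c1cc(C(=O)N[C@@H]2CN[C@H](CC(N)=O)C[C@H]2c2ccc(Cl)c(Cl)c2)oc1Cl`) gives 1000 nM on the same core. Compound 3 (`Cn1ncc(Cl)c1-c1cc(C(=O)N[C@@H]2CN[C@H](CCN3CCCC3)C[C@H]2c2ccc(Cl)c(Cl)c2)oc1Cl`) gives 1840 nM and stands level with both. Its gaps to them (a 1.2-fold higher number from compound 1 to compound 3 (0.07 log units; within the scatter) and a 1.8-fold higher number from compound 2 to compound 3 (0.26 log units; within the scatter)) stay within the scatter.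

Compound 4 (`Cn1ncc(Cl)c1-c1cc(C(=O)N[C@@H]2CN[C@H](CC(=O)NCCO)C[C@H]2c2ccc(Cl)c(Cl)c2)oc1Cl`) alters one group of compound 3 ((2-hydroxyethyl)carbamoyl in place of (pyrrolidin-1-yl)methyl on a saturated chain carbon bound to a saturated ring carbon): (2-hydroxyethyl)carbamoyl in place of (pyrrolidin-1-yl)methyl on a saturated chain carbon bound to a saturated ring carbon. The closest evidence is compound 2, which carries a plain carbamoyl there. Its other measured step (a 1.6-fold lower number from compound 1 to compound 2 (0.19 log units; within the scatter)) is also within the scatter. For the measured compounds named here, no measured compound carries a substituted carbamoyl, so that part remains untested. Among these three compounds, no swap moved the number beyond the scatter, so none is expected in this assay here. The expected step is small, a 1.5-fold lower number from compound 3 to compound 4 (0.19 log units; within the scatter) and drifting towards compound 2 at most. For compound 4 the estimated value is 1200 nM with a range from 550 nM to 2500 nM expected.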

Compound 4, half-maximal inhibitory concentration: 1450 nM
Compound 4: middle estimate off by 1.2-fold (0.08 log units), on the low side; the measured number falls inside the stated range.
By their numbers in this assay, from the lowest: compounds 2, 4, 1 and 3 (each within the scatter of the next).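

In this assay, a substituted carbamoyl at this place, on a saturated chain carbon bound to a saturated ring carbon, stays level with the groups already seen there, whether it replaces a ring-bearing group (a 1.3-fold lower number from compound 3 to compound 4 (0.10 log units; within the scatter)) or another ring-bearing group (a 1.1-fold lower number from compound 1 to compound 4 (0.03 log units; within the scatter)). For the compounds shown here, putting 2-hydroxyethyl in place of hydrogen on an amide-type nitrogen also stays within the scatter (a 1.5-fold higher number from compound 2 to compound 4 (0.16 log units; within the scatter)), so the amide hydrogen of compound 2 can be replaced by this chain with no measurable step. Nothing available here explains why these four different groups read alike.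

The compounds shown leave open how a carboxylic acid or a primary amine at this place would read. They also leave open whether a longer chain on the amide-type nitrogen would stay level.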